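Pyrimidin-2-yl for pyridazin-3-yl: permeability notes

A few compounds are considered here, and "the series" means these few. Any claim that something is new, unique, unknown or untested is made for them only; others in the source may bear on it.

The series shares one core; compound 1 is `C[C@@H](Oc1cc2oc(=O)n(CCC(=O)O)c2cc1Cl)c1ccc(Cl)cn1`, compound 2 is `CCOc1cc2oc(=O)n(CCC(=O)O)c2cc1Cl`, compound 3 is `C[C@@H](Oc1cc2oc(=O)n(CCC(=O)O)c2cc1Cl)c1cccnn1`, and compound 4, not yet measured, is `C[C@@H](Oc1cc2oc(=O)n(CCC(=O)O)c2cc1Cl)c1ncccn1`. In a physicochemical assay for permeability, using PAMPA (on this read-out lower numbers stand for lower permeability and higher numbers for higher permeability), compound 1 gives 60 nm/s. Compound 2 reaches only a limit of this assay, < 10 nm/s. Compound 3 likewise reaches only a limit, < 3 nm/s, so compound 3 stands at the lowest end of the numbers shown, without an exact figure. The step of an at least 6.0-fold lower number from compound 1 to compound 2 (0.77 log units; beyond the scatter) and the step of an at least 20-fold lower number from compound 1 to compound 3 (1.30 log units; beyond the scatter) both run downward, the second one large; the step that the two limits leave unreadable from compound 2 to compound 3 cannot be read, since both of its ends are limits. Compound 4 differs from compound 3 by pyrimidin-2-yl in place of pyridazin-3-yl on a saturated chain carbon bound to an oxygen on an aromatic ring and a saturated chain carbon; the two hold the same atoms joined differently. Going by the values given here, no measured step exchanges one ring of this kind for another, so the only bearing comes from an at least 20-fold lower number from compound 1 to compound 3 (1.30 log units; beyond the scatter), which sets the level reached once pyridazin-3-yl sits at this place. For compound 4 the step of an at least 1.3-fold higher number from compound 3 to compound 4 (0.12 log units; that floor lies within the scatter) is expected to stay within the scatter, with the result most likely again a limit rather than a number. Compound 4 is estimated at 4 nm/s, between 1 nm/s and 12 nm/s.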

Compound 4, apparent permeability: < 3 nm/s
Compound 4 gave a limit, no number (the forecaster's own chance of this, stated with the estimate: 60%); middle value at least 1.3-fold (0.12 log units) from the limit.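

Pyrimidin-2-yl in place of 5-chloropyridin-2-yl on this saturated chain carbon gives an at least 20-fold lower number from compound 1 to compound 4 (1.30 log units; beyond the scatter), so the loss at this place in this assay is not confined to pyridazin-3-yl. Two rings with the same atoms joined differently now end at the same limit, which marks the floor of the read-out and not a measured level: the limit of < 3 nm/s in this assay, at which 2 of the 4 values shown sit. The steps from compound 3 to compound 4 and from compound 2 to compound 4 cannot be read, so no order among these compounds follows, and any difference between pyridazin-3-yl and pyrimidin-2-yl remains hidden beneath that limit.

The compounds shown do not separate the effect of the chlorine on 5-chloropyridin-2-yl from that of the second ring nitrogen, a question that pyridin-2-yl or 5-chloropyrimidin-2-yl at this place would address. On these data alone, whether a methyl ester in place of the carboxylic acid would bring compound 3 or compound 4 up to a readable number also stays open.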